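A few compounds are considered here, and "the series" means these few. Any claim that something is new, unique, unknown or untested is made for them only; others in the source may bear on it.

Compounds 1, 2 and 3 share one core and differ only in the aryl group on the saturated ring carbon. Compound 1 `COc1cc2c(Oc3ccc(NC(=O)NN4C(=O)CSC4c4ccccc4)cc3)ccnc2cc1OC1CCN(C(=O)NC(C)C)CC1` gives 1260 nM in a functional assay on HT-29 cells (Homo sapiens) for inhibition, read by MTT assay; a lower number here means a stronger inhibitor, a higher number a weaker inhibitor. Compound 2 `COc1cc2c(Oc3ccc(NC(=O)NN4C(=O)CSC4c4ccc(F)c(F)c4)cc3)ccnc2cc1OC1CCN(C(=O)NC(C)C)CC1` gives 1060 nM in this assay, a change of a 1.2-fold lower number from compound 1 to compound 2 (0.08 log units; within the scatter). Compound 3 `COc1cc2c(Oc3ccc(NC(=O)NN4C(=O)CSC4c4c(F)cccc4F)cc3)ccnc2cc1OC1CCN(C(=O)NC(C)C)CC1` gives 310 nM in this assay, the lowest of the three numbers, with steps of a 4.1-fold lower number from compound 1 to compound 3 (0.61 log units; beyond the scatter) and a 3.4-fold lower number from compound 2 to compound 3 (0.53 log units; beyond the scatter).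

Compound 4 `COc1cc2c(Oc3ccc(NC(=O)NN4C(=O)CSC4c4c(F)cc(F)cc4F)cc3)ccnc2cc1OC1CCN(C(=O)NC(C)C)CC1` differs from compound 3 by fluoro in place of hydrogen on an aromatic carbon. Going by the values given here, no measured step adds a single fluoro to an aryl group already bearing two; the nearest precedents are the steps from compound 1, where the 3,4-difluoro pattern moved the number little and the 2,6-difluoro pattern moved it modestly. Since compound 4 keeps the 2,6-difluoro pattern of compound 3, the expected step in this assay is small, with no firm direction, and is estimated at a 1.0-fold lower number from compound 3 to compound 4 (0.01 log units; within the scatter). Compound 4 is therefore expected to give about 300 nM in this assay, within a range of 120 nM to 750 nM.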

Compound 4, half-maximal inhibitory concentration: 910 nM
Compound 4: the middle estimate sits 3.0-fold (0.48 log units) below what was measured; the measured number lies above the stated range.
By their numbers in this assay, from the lowest: compound 3; then compounds 4, 2 and 1 (each within the scatter of the next).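

Adding a fluoro to the 2,6-difluorophenyl group, on the aromatic carbon meta to two fluoro groups and para to a large group, is not a neutral change in this assay: the result is a 2.9-fold higher number from compound 3 to compound 4 (0.47 log units; beyond the scatter) in this cell assay. The 2,6-difluoro pattern alone therefore does not secure the low number of compound 3. With the added fluoro, the number no longer stands apart from those of the other aryl groups, with a 1.2-fold lower number from compound 2 to compound 4 (0.07 log units; within the scatter) and a 1.4-fold lower number from compound 1 to compound 4 (0.14 log units; within the scatter) both read as no real difference.

No measurement shown here explains why this one fluoro has this effect. As far as these compounds go, whether a chloro, methyl, methoxy or amino group on the same carbon would behave like the fluoro or like the hydrogen remains open.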